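This account rests on a few compounds, and the source may have more. Where it says the series, first, only, none or still open, it means among the compounds named here.

Measured in a functional assay on A-375 cells (Homo sapiens) for cytotoxicity, read by CCK-8 assay, with a stated time of 24 h; a lower number here means a stronger inhibitor, a higher number a weaker inhibitor:
Compound 1 `COc1cccc(-c2nc(N)c(Oc3ccccc3OC)c(Cl)n2)c1`: 24600 nM
Compound 2 `COc1ccc(-c2nc(N)c(Oc3ccccc3OC)c(Cl)n2)cc1`: > 80000 nM (a limit, not a number)

Compound 2 sits at the limit of > 80000 nM in this assay, at which 1 of the 2 values shown sits. The next compound, compound 3 `COc1ccccc1Oc1c(N)nc(-c2ccc(Cl)cc2)nc1Cl`, carries chloro in place of methoxy on an aromatic carbon, para to a large group (chloro in place of methoxy on an aromatic carbon). Read one bond further out, this is 4-methoxyphenyl to 4-chlorophenyl.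

For the measured compounds named here, one measured step bears on this change: an at least 3.2-fold higher number from compound 1 to compound 2 (0.51 log units; beyond the scatter). It shows that a change in the methoxy-bearing aryl group can shift the reading beyond the scatter, but that step exchanged no group for chloro, so it offers only a rough guide to size. Compound 1 gives 24600 nM, which shows that a measurable number is possible with this core. A modest move toward a lower number is therefore expected, an estimated at least 2.2-fold lower number from compound 2 to compound 3 (0.35 log units; beyond the scatter). Compound 3 is expected at 35000 nM, with an estimated range from 12000 nM to 80000 nM.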

Compound 3, half-maximal inhibitory concentration: 1030 nM
Compound 3: the middle estimate sits 34-fold (1.53 log units) above what was measured; the measured number lies below the stated range.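

Placing chloro where methoxy stood gives an at least 77-fold lower number from compound 2 to compound 3 (1.89 log units; beyond the scatter) in this assay, so the group at this place can do far more than the earlier compounds showed. Compound 2 has a limit, not a number: the limit of > 80000 nM in this assay, at which 1 of the 3 values shown sits. The comparison with a compound that has a measured value gives a 24-fold lower number from compound 1 to compound 3 (1.38 log units; beyond the scatter), so the 4-chlorophenyl compound also stands clearly apart from compound 1, and its low number is not seen only against a limit.

From the compounds shown here alone, whether fluoro, bromo, trifluoromethyl or an amine at this place would give a similar number stays open. A plain phenyl group would help to show whether chloro lowers the number, methoxy raises it, or both.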